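From 4-methylphenyl to 4-fluorophenyl in a two-compound series

This account rests on a few compounds, and the source may have more. Where it says the series, first, only, none or still open, it means among the compounds named here.

Of the compounds shown here, two have been measured so far in a functional assay (plasma) for inhibition, with Homo sapiens as the target; a higher number here means a weaker inhibitor, a lower number a stronger inhibitor. Compound 1 (`O=C(O)CCC/C=C\C[C@H]1C(=O)CC[C@@H]1NS(=O)(=O)c1ccc(Cl)cc1`) gives 640 nM. Among the compounds with values here, compound 2 (`Cc1ccc(S(=O)(=O)N[C@H]2CCC(=O)[C@@H]2C/C=C\CCCC(=O)O)cc1`) gives 670 nM, and the two values lie within the scatter of each other, so compound 2 is not separated from its only neighbour.

Compound 3 (`O=C(O)CCC/C=C\C[C@H]1C(=O)CC[C@@H]1NS(=O)(=O)c1ccc(F)cc1`) keeps the shared core and changes a single group of compound 2: fluoro in place of methyl on an aromatic carbon. This is fluoro in place of methyl on an aromatic carbon, para to a large group.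

Within the data shown here, one measured step bears on this change. The swap of methyl in place of chloro on an aromatic carbon gave a 1.0-fold higher number from compound 1 to compound 2 (0.02 log units; within the scatter), which is within the scatter. Among the measured compounds shown here, that is a single step, and no fluoro compound has a measured value yet. No change beyond the scatter is therefore expected in this assay. The expected step is a 1.0-fold lower number from compound 2 to compound 3 (0.01 log units; within the scatter). For compound 3 the estimated value is 650 nM, with an expected range of 300 nM to 1400 nM.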

Compound 3, half-maximal inhibitory concentration: 500 nM
Estimate against measurement, compound 3: 1.3-fold (0.11 log units) above, and the stated range covers the measured number.
By their numbers in this assay, from the lowest: compounds 3, 1 and 2 (each within the scatter of the next).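

In this assay, the aromatic position para to a large group has now been read with three groups: chloro, methyl and fluoro. Fluoro in place of methyl gives a 1.3-fold lower number from compound 2 to compound 3 (0.13 log units; within the scatter), and fluoro in place of chloro gives a 1.3-fold lower number from compound 1 to compound 3 (0.11 log units; within the scatter). Within the data shown here, both steps lie within the scatter, so fluoro joins chloro and methyl without separating from either, which extends what the single earlier step showed for chloro and methyl alone, and no information is available to explain this flat reading.

Still open, going by these compounds, is whether any group at this position would move the number beyond the scatter, for example methoxy, trifluoromethyl, nitrile, an amine or a second phenyl ring. The shared core and the chain ending in the carboxylic acid are the same in compound 1, compound 2 and compound 3, so these compounds say nothing about an ester or an amide in place of that acid, or about a shorter or longer chain, in this assay.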